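Aryl swap on the amide: compound 3 to compound 4

This account rests on a few compounds, and the source may have more. Where it says the series, first, only, none or still open, it means among the compounds named here.

compound 1 `Cc1ccc(NC(=O)CN2CCN(c3nnc(Cc4ccncc4)c4ccccc34)CC2)c(C)c1` gives 45000 nM 
compound 2 `Cc1ccc(F)cc1NC(=O)CN1CCN(c2nnc(Cc3ccncc3)c3ccccc23)CC1` gives 38900 nM 
compound 3 `O=C(CN1CCN(c2nnc(Cc3ccncc3)c3ccccc23)CC1)Nc1ccc(F)c(Cl)c1` gives 12300 nM 

All three numbers come from a functional assay on A549 cells (Homo sapiens) for cytotoxicity, read by MTT assay, with a stated time of 72 h (a higher number here means a weaker inhibitor, a lower number a stronger inhibitor), and the compounds differ only in the aryl group on the amide. Compound 3 stands lowest of the three, and its distance to each of the other two lies beyond the scatter.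

The next compound is compound 4 `Cc1ccccc1NC(=O)CN1CCN(c2nnc(Cc3ccncc3)c3ccccc23)CC1`, not yet measured. The change from compound 3 is 2-methylphenyl in place of 3-chloro-4-fluorophenyl on an amide-type nitrogen.

Among the measured compounds shown here, three measured steps bear on this. The number fell by a 3.7-fold lower number from compound 1 to compound 3 (0.56 log units; beyond the scatter) and by a 3.2-fold lower number from compound 2 to compound 3 (0.50 log units; beyond the scatter) on reaching the 3-chloro-4-fluorophenyl group, both modest in size. The remaining step, a 1.2-fold lower number from compound 1 to compound 2 (0.06 log units; within the scatter), lies within the scatter, so those two compounds form a single level. Like compound 1 and compound 2, compound 4 carries a methyl group on its aryl ring and no chlorine, so it is expected to return to that level, though this rests on only three compounds. The expected step is a 3.1-fold higher number from compound 3 to compound 4 (0.49 log units; beyond the scatter) and would be modest, toward a higher number in this assay overall. The estimate for compound 4 is 38000 nM with an expected range of 18000 nM to 80000 nM for repeated measurements.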

Compound 4, half-maximal inhibitory concentration: 43100 nM
Compound 4: middle estimate off by 1.1-fold (0.05 log units), on the low side; low and high end bracket the measured number.
By their numbers in this assay, from the lowest: compound 3; then compounds 2, 4 and 1 (each within the scatter of the next).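

In this assay, the 2-methylphenyl group of compound 4 sits at one level with the more substituted rings: a 1.1-fold higher number from compound 2 to compound 4 (0.04 log units; within the scatter) with hydrogen in place of fluoro, and a 1.0-fold lower number from compound 1 to compound 4 (0.02 log units; within the scatter) with hydrogen in place of methyl, so neither the fluoro of compound 2 nor the additional methyl of compound 1 shifts the number beyond the scatter. The step of a 3.5-fold higher number from compound 3 to compound 4 (0.54 log units; beyond the scatter) shows that the separation of compound 3 also holds against the simplest methyl-bearing ring in the set, leaving the 3-chloro-4-fluorophenyl group alone at the lower level, with compounds 1, 2 and 4 together at the higher one. No measurement is at hand that explains this separation.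

Compound 3 differs from the other three in several features at once, so the chlorine, its fluoro, and the absence of a methyl group remain unseparated as sources of its step. Going by these compounds, a plain phenyl ring, a phenyl ring carrying chlorine alone, and a ring carrying both chlorine and methyl would divide these, while an amine or a carboxylic acid on the ring remains open territory at this position.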